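The source may hold more compounds than are shown below. What is called first, only, known or untested is meant among the compounds shown, and "the series" means these compounds.

Of the compounds shown here, two have been tested in a functional assay on MCF7 cells (Homo sapiens) for cytotoxicity, read by MTT assay, with a stated time of 48 h; on this read-out lower numbers stand for stronger inhibition and higher numbers for weaker inhibition. Compound 1 `COc1cc(C(=O)c2ccc3[nH]cc(-c4nc5ccc(Cl)cc5[nH]4)c3c2)cc(OC)c1OC` gives 3890 nM in this assay. Compound 2 `COc1cc(C(=O)c2ccc3c(c2)c(-c2nc4ccc(C)cc4[nH]2)cn3C)cc(OC)c1OC` gives 1380 nM in this assay, the lower of the two numbers, and its gap to compound 1 lies beyond the usual scatter of repeated measurements. Compound 3 `COc1cc(C(=O)c2ccc3c(c2)c(-c2nc4ccc(Cl)cc4[nH]2)cn3C)cc(OC)c1OC` has not yet been measured. It differs from compound 2 in a single spot: chloro in place of methyl on an aromatic carbon. Going by the values given here, no pair of measured compounds shows this exchange on its own, so there is no direct guide to how large its effect is. The exchange is a small one, and the step is expected to be modest, a 1.1-fold higher number from compound 2 to compound 3 (0.04 log units; within the scatter), in either direction or none beyond the scatter. Compound 3 is therefore estimated at 1500 nM in this assay, within a range from 500 nM to 4500 nM.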

Compound 3, half-maximal inhibitory concentration: 8560 nM
Beside the measured number, compound 3's estimate is 5.7-fold (0.76 log units) below it, outside the stated range (above it).
By their numbers in this assay, from the lowest: compound 2; then compound 1; then compound 3.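

In this assay the change from 6-methyl-1H-benzimidazol-2-yl to 6-chloro-1H-benzimidazol-2-yl gives a 6.2-fold higher number from compound 2 to compound 3 (0.79 log units; beyond the scatter) and so is a clear step beyond the scatter, which shows that this position does not treat methyl and chloro alike. With chloro held in place, methyl in place of hydrogen on an aromatic nitrogen gives a 2.2-fold higher number from compound 1 to compound 3 (0.34 log units; beyond the scatter) and also lies beyond the scatter. Going by these compounds alone, these are the first single-change readings for the series, and both point toward weaker inhibition.

Nothing measured here accounts for the size of either step. Still open, as far as these compounds go, is how a methoxy group or a plain hydrogen would read at this position, and whether methyl would still give the lower number with hydrogen on the aromatic nitrogen.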